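A few compounds are considered here, and "the series" means these few. Any claim that something is new, unique, unknown or untested is made for them only; others in the source may bear on it.

Compounds measured so far:
Compound 1, `O=C(CCCN1CCC(n2c(C(F)(F)F)nc3ccccc32)CC1)c1ccc(F)cc1`: "not determined" (no result reported)
Compound 2, `O=C(CCCN1CCC(n2c(SCCO)nc3ccccc32)CC1)c1ccc(F)cc1`: > 3 mg/kg

In a functional assay on the whole organism (strain STD-ddY) with Mus musculus as the target, with stated times of 1 h and 24 h (on this read-out lower numbers stand for an effect already at smaller amounts and higher numbers for an effect only at larger amounts of compound), compound 1 gives "not determined" (no result reported), so no number stands beside it. For compound 2 only a limit of this assay is reported, > 3 mg/kg, not a number. Compound 2 thus sits at the limit of > 3 mg/kg in this assay, at which 1 of the 2 values shown sits. Compound 3, `CCOC(=O)Sc1nc2ccccc2n1C1CCN(CCCC(=O)c2ccc(F)cc2)CC1`, has not yet been tested in this assay; it differs from compound 2 by ethoxycarbonyl in place of 2-hydroxyethyl on a sulfur. Among the measured compounds shown here, no step between two measured compounds is available here, so the size of the change from compound 2 to compound 3 in this assay can only be expected, not read off. Compound 3 is expected to shift by a step that the limit leaves unreadable from compound 2 to compound 3, which is no change beyond the scatter, with a good chance that the assay again reports only a limit. Compound 3 is estimated at 5 mg/kg, with a range from 2 mg/kg to 30 mg/kg.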

Compound 3, dose for half-maximal effect: 0.65 mg/kg
Estimate against measurement, compound 3: 7.7-fold (0.89 log units) above, outside the stated range (below it).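

In this assay, placing ethoxycarbonyl instead of 2-hydroxyethyl on the sulfur gives an at least 4.6-fold lower number from compound 2 to compound 3 (0.66 log units; beyond the scatter). This shows that the read-out responds to the group at this sulfur, and compound 3 is the first of the compounds shown to carry a single number rather than a limit. The true size of the step stays unknown, as the value for compound 2 is only a limit: the limit of > 3 mg/kg in this assay, at which 1 of the 3 values shown sits.

Steps involving compound 1 cannot be read, as it has no result in this assay. Going by these compounds, it also remains open whether the ethoxycarbonyl group as a whole matters or only part of it, and how an acetyl group, a plain ethyl group or a chain ending in an amine on the same sulfur would read in this assay.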